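Amide-side aryl exchange in a benzylic sulfonamide series

This account rests on a few compounds, and the source may have more. Where it says the series, first, only, none or still open, it means among the compounds named here.

Measured so far:
compound 1, `O=C(NCc1ccc(CNS(=O)(=O)c2ccc3c(c2)CCO3)cc1)c1cccc2c1COC2`, gives 1000 nM in an assay on cells for displacement of a labelled ligand from C-X-C chemokine receptor type 4 (Homo sapiens), read by fluorescence and microscopy, with stated times of 10 min and 30 min; a lower number here means that less compound is needed, a higher number that more compound is needed for the effect.
compound 2, `O=C(NCc1ccc(CNS(=O)(=O)c2ccc(F)c(F)c2)cc1)c1cnc2ccccn12`, gives > 1000 nM in this assay.

Compound 2 sits at a limit of this assay rather than a number (the limit of > 1000 nM in this assay, at which 1 of the 2 values shown sits). Only compound 1 gives a value. Compound 3, `Cc1nnsc1C(=O)NCc1ccc(CNS(=O)(=O)c2ccc(F)c(F)c2)cc1`, differs from compound 2 in one place: a group of 6 heavy atoms (3 carbon, 2 nitrogen, 1 sulfur; one five-membered aromatic ring with 3 hetero atoms) in place of a group of 9 heavy atoms (7 carbon, 2 nitrogen; one five-membered aromatic ring with 2 hetero atoms, one six-membered aromatic ring with 1 hetero atom), on a carbonyl carbon. Within the data shown here, no step between measured compounds is available to anchor this change, so no shift beyond the usual scatter is expected in this assay. Compound 3 is therefore estimated at 1500 nM (range 500 nM to 5000 nM), an expected step that the limit leaves unreadable from compound 2 to compound 3.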

Compound 3, effective concentration (reported as EC, without a stated level of effect): 10 nM
Compound 3: middle estimate off by 150-fold (2.18 log units), on the high side, and the stated range ends above it.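

On the carbonyl carbon next to the amide-type nitrogen, this position now shows a clear response in this assay: 4-methyl-1,2,3-thiadiazol-5-yl, entering for the group with one five-membered and one six-membered aromatic ring, gives a large change (an at least 100-fold lower number from compound 2 to compound 3 (2.00 log units; beyond the scatter)). The earlier compounds shown here offered no step at this position. Compound 2 gives a limit, not a number, so the true size of the step stays unknown: the limit of > 1000 nM in this assay, at which 1 of the 3 values shown sits.

Whether the methyl or the ring carries the change remains open, as no unsubstituted 1,2,3-thiadiazol-5-yl or ethyl analogue is shown. Also open, as far as these compounds go, is whether 4-methyl-1,2,3-thiadiazol-5-yl acts the same way with the sulfonyl group of compound 1.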